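The source may report more compounds than this note shows. Statements on the series, on what has been measured and on what is new or still open speak of the compounds shown alone.

In a functional assay on FaDu cells (Homo sapiens) for cytotoxicity, read by MTT assay, with a stated time of 72 h (on this read-out lower numbers stand for higher toxicity in this test and higher numbers for lower toxicity in this test), compound 1 (`COc1ccc(NC(=O)C(=O)c2cn(C(C)C)c3ccccc23)cn1`) gives 85 nM as its reading. Compound 2 (`CCC(C)n1cc(C(=O)C(=O)Nc2ccc(OC)nc2)c2ccccc21`) gives 68 nM as its reading, and the two numbers lie within the scatter of each other, so compound 1 holds no separate rank. Compound 3 (`COc1ccc(NC(=O)C(=O)c2cn(C(C)C)c3cc(Cl)ccc23)cn1`) differs from compound 1 by chloro in place of hydrogen on an aromatic carbon. Among the measured compounds shown here, only one measured step is available, a 1.3-fold lower number from compound 1 to compound 2 (0.10 log units; within the scatter) (methyl in place of hydrogen on a saturated chain carbon). That change lies on the chain rather than on the aromatic carbon altered in compound 3, so it bears on the new change only indirectly. For the measured compounds named here, no measured compound carries chloro, and the data contain no step of this kind. The expectation is therefore modest: no step beyond the scatter in this assay and no favoured direction, with a wide margin for the untested change. The expected step is a 1.1-fold lower number from compound 1 to compound 3 (0.03 log units; within the scatter) as a rough estimate. For compound 3 the estimated value is 80 nM with an expected range from 25 nM to 260 nM in this test.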

Compound 3, concentration lethal to 50% of the cells: 1770 nM
Compound 3: middle estimate off by 22-fold (1.34 log units), on the low side; the whole stated range lies below it.
By their numbers in this assay, from the lowest: compounds 2 and 1 (each within the scatter of the next); then compound 3.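

In this assay, among the compounds shown here, this aromatic carbon, meta to a fused ring and para to a fused ring, is the first place where a single change moves the reading beyond the scatter, with a 21-fold higher number from compound 1 to compound 3 (1.32 log units; beyond the scatter), a large step towards lower toxicity in this test. The change adds only one heavy atom, a chlorine, yet the only earlier step, a 1.3-fold lower number from compound 1 to compound 2 (0.10 log units; within the scatter), made on the saturated chain, stayed within the scatter, so the reading is shown to respond far more to this change on the aromatic carbon than to that one on the chain. The data offer no measurement that would account for the size of this step.

A single substituent at a single carbon cannot show whether the step belongs to chloro itself or to any replacement of hydrogen there, so fluoro, methyl, methoxy or an amine at the same carbon would each be needed to tell these apart. Going by these compounds, it also remains open whether chloro on another carbon of this six-membered ring would give a similar step, and whether the step would keep its size on the chain carried by compound 2.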